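From Fluoro to Chloro on One Aromatic Carbon

The compounds below may be only part of what the source reports. "The series", "measured", "known", "first", "only" and "open" are said of these compounds alone.

Among the measured compounds shown here, in a functional assay on the whole organism for antagonist activity, with Mus musculus as the target (on this read-out higher numbers stand for an effect only at larger amounts of compound and lower numbers for an effect already at smaller amounts), compound 1 `CSc1nnc(-c2ccc(F)cc2)n1C` gives 33.4 mg/kg as the only true number so far. Compound 2 `Cn1c(-c2cccc3ccccc23)nnc1S(C)(=O)=O` stands at > 200 mg/kg in this assay and this is a limit of the measurement, not a number. Compound 3 `CSc1nnc(-c2ccc(Cl)cc2)n1C` differs from compound 1 in one place, with chloro in place of fluoro on an aromatic carbon. For the measured compounds named here, no measured pair shows what this swap does, so in this assay a change within the usual scatter is expected, in neither direction. The estimated 1.1-fold lower number from compound 1 to compound 3 (0.05 log units; within the scatter) is therefore small. Compound 3 is expected to give 30 mg/kg with an estimated range from 12 mg/kg to 80 mg/kg around it.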

Compound 3, dose for half-maximal effect: 28.1 mg/kg
Compound 3: the middle estimate sits 1.1-fold (0.03 log units) above what was measured; measured number inside the range.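

In this assay, among the compounds shown here, the first measured pair at this position gives a 1.2-fold lower number from compound 1 to compound 3 (0.08 log units; within the scatter). Chloro in place of fluoro on an aromatic carbon, para to a group of 8 heavy atoms, thus leaves the read-out within the scatter, and these two groups cannot be told apart here.

On these data alone, whether an amine, a carboxylic acid or a longer chain on this carbon would also leave the number in place remains open. No measurement shown speaks to what lies behind this result.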